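A Single Methyl Added to Compound 2

The source may hold more compounds than are shown below. What is called first, only, known or untested is meant among the compounds shown, and "the series" means these compounds.

In a functional assay on K562 cells (Homo sapiens) for cytotoxicity, with a stated time of 72 h (on this read-out higher numbers stand for weaker inhibition and lower numbers for stronger inhibition), compound 2 `CC1(C)Cc2c(-c3ccncc3)c(-c3ccccn3)nn2C1` gives > 100000 nM, which is a limit of the assay and not a number. Compound 1 `Cc1cccc(-c2nn3c(c2-c2ccncc2)C(CO)C(C)(C)C3)n1` gives > 100000 nM, which is also a limit. The evidence so far is therefore (the limit of > 100000 nM in this assay, at which 2 of the 2 values shown sit).

Compound 3 `Cc1cccc(-c2nn3c(c2-c2ccncc2)CC(C)(C)C3)n1` differs from compound 2 by one small change, a methyl in place of hydrogen on an aromatic carbon. The pyridin-2-yl group thus becomes 6-methylpyridin-2-yl. Compound 1 already carries that 6-methylpyridin-2-yl group and gives > 100000 nM in this assay, again a limit, so no step beyond the scatter is expected, in either direction. The expected change is a number no higher from compound 2 to compound 3 (the limit leaves the size open). For compound 3 the estimated value is 100000 nM, with an expected range of 40000 nM to 200000 nM.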

Compound 3, half-maximal inhibitory concentration: > 100000 nM
Compound 3 was reported as a limit; the forecaster's own chance of this, stated with the estimate: 85%; the middle value lies on the limit itself.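

In this assay, going by these compounds alone, compound 3 gives > 100000 nM, a limit and not a number, so no step from it to compound 1 or compound 2 can be read. The compounds shown leave open whether the methyl or the hydroxymethyl group changes this read-out at all.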